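Ester variation on the shared core: a chloro on the phenyl

The source may hold more compounds than are shown below. What is called first, only, known or untested is meant among the compounds shown, and "the series" means these compounds.

Measured compounds:
compound 1, `CC(=O)O[C@]12C=CC(=O)C[C@H]1OCC2`: 0.5 ug/mL
compound 2, `CCCC(=O)O[C@]12C=CC(=O)C[C@H]1OCC2`: 0.6 ug/mL
compound 3, `O=C1C=C[C@]2(OC(=O)c3ccccc3)CCO[C@@H]2C1`: 0.5 ug/mL

All three numbers come from a functional assay on P388 cells (Mus musculus) for cytotoxicity; on this read-out higher numbers stand for weaker inhibition and lower numbers for stronger inhibition. Compound 3 sits level with compound 1 at the digits shown, the two of them together the lowest of the three numbers; from compound 3 the nearest is compound 1 and the furthest compound 2, and every gap is within the scatter. The steps measured so far all change the acyl part of the ester on the shared core: a 1.2-fold higher number from compound 1 to compound 2 (0.08 log units; within the scatter); no change at the digits printed from compound 1 to compound 3 (within the scatter); a 1.2-fold lower number from compound 2 to compound 3 (0.08 log units; within the scatter). None of them moves the number beyond the scatter.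

Compound 4, `O=C1C=C[C@]2(OC(=O)c3ccccc3Cl)CCO[C@@H]2C1`, differs from compound 3 by chloro in place of hydrogen on an aromatic carbon. Among the compounds with values here, no measured step touches the phenyl ring itself, so the closest guide is that exchanging methyl, propyl and phenyl on the carbonyl carbon left the numbers flat. By that guide no step beyond the scatter is expected in this assay, in either direction: the step from compound 3 is estimated as no change at the digits printed from compound 3 to compound 4 (within the scatter). Compound 4 is therefore expected to give 0.5 ug/mL in this assay, with a range from 0.25 ug/mL to 1 ug/mL.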

Compound 4, half-maximal inhibitory concentration: 0.4 ug/mL
For compound 4 the middle estimate is 1.3-fold (0.10 log units) above the measured one, and the stated range covers the measured number.
By their numbers in this assay, from the lowest: compounds 4, 1, 3 and 2 (each within the scatter of the next).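

In this assay, the first change made on the phenyl ring itself, chloro in place of hydrogen on an aromatic carbon, ortho to a large group, gives a 1.3-fold lower number from compound 3 to compound 4 (0.10 log units; within the scatter) and so stays within the scatter. Earlier steps exchanged the whole group on the carbonyl carbon; this one shows that the ring of compound 3 can carry a chloro at this position with no reading beyond the scatter, which extends the flat picture from the acyl group as a whole to a single ring position. No evidence bearing on this result is available, so the flat reading has no stated explanation.

The compounds shown leave open whether any change to the ester moves the number beyond the scatter, since a single substituent at a single ring position cannot show how the other aromatic carbons respond. An amine or a carboxylic acid on the phenyl ring, or an ester-linked chain carrying either group, would test whether this flatness holds for groups other than chloro.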